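Dihydroxyphenyl in Place of Methoxyphenyl: Compound 3 Expected

The compounds below may be only part of what the source reports. "The series", "measured", "known", "first", "only" and "open" are said of these compounds alone.

Going by the values given here, compound 1 `COc1cccc(/C=C2\CCC/C(=C\c3cccc(OC)c3OC)C2=O)c1` gives 16400 nM in a functional assay on A549 cells (Homo sapiens) for cytotoxicity, read by MTT assay, with a stated time of 72 h (a higher number here means a weaker inhibitor, a lower number a stronger inhibitor), the higher of the two numbers known, while compound 2 `COc1cc(/C=C2\CCC/C(=C\c3cccc(OC)c3OC)C2=O)cc(OC)c1` gives 10200 nM and a 1.6-fold lower number from compound 1 to compound 2 (0.21 log units; within the scatter). Compound 3 `COc1cccc(/C=C2\CCC/C(=C\c3ccc(O)c(O)c3)C2=O)c1OC` differs from compound 1 in one place: 3,4-dihydroxyphenyl in place of 3-methoxyphenyl on a double-bonded chain carbon bound to a double-bonded ring carbon. Among the compounds with values here, no measured step exchanges one aryl group for another, and the only step known, that from compound 1 to compound 2, lay within the scatter. Compound 3 is therefore expected to show no change beyond the scatter, with a 1.4-fold lower number from compound 1 to compound 3 (0.14 log units; within the scatter). Compound 3 is estimated at 12000 nM, within a range of 4000 nM to 40000 nM.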

Compound 3, half-maximal inhibitory concentration: > 20000 nM
Compound 3: only a limit was reported; the forecaster's own chance of this, stated with the estimate: 5%; at least 1.6-fold (0.22 log units) between middle value and limit.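

The aryl group on a double-bonded chain carbon bound to a double-bonded ring carbon can be exchanged, and in this assay this change gives an at least 1.2-fold higher number from compound 1 to compound 3 (0.08 log units; that floor lies within the scatter). The step offers no sign that 3,4-dihydroxyphenyl, with its hydrogen-bond donors, strengthens the compound. Compound 3 is reported only as a limit, so the true size of the step stays unknown: the limit of > 20000 nM in this assay, at which 1 of the 3 values shown sits.

On these data alone, whether an amine or a carboxylic acid on this aryl ring would behave differently remains open. So does how far the true value of compound 3 lies beyond its limit.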